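Methoxy in place of bromo: compound 1 to compound 4

This account rests on a few compounds, and the source may have more. Where it says the series, first, only, none or still open, it means among the compounds named here.

Measured compounds in a functional assay on CCRF-CEM cells (Homo sapiens) for cytotoxicity, with a stated time of 72 h; a lower number here means a stronger inhibitor, a higher number a weaker inhibitor:
compound 1, `C#CCOc1ccc(/C=C/C(=O)c2cccc(Br)c2)cc1OC`: 15200 nM
compound 2, `C#CCOc1ccc(C(C)=O)cc1CC=C`: 38200 nM
compound 3, `C#CCOc1ccc(/C=C/C(=O)c2ccc(C(C)C)cc2)cc1CC=C`: 11900 nM

Of the three numbers, compound 1 has the second highest. Compound 3 gives 11900 nM, which lies within the scatter of compound 1, so the two cannot be ordered. Compound 2 gives 38200 nM, a gap beyond the scatter, and it is the only one of the three that clearly separates from compound 1.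

Compound 4, `C#CCOc1ccc(/C=C/C(=O)c2cccc(OC)c2)cc1OC`, has not been measured. It differs from compound 1 in one place: methoxy in place of bromo on an aromatic carbon. Going by the values given here, no pair of measured compounds carries this change, so the series itself offers no step to read it from; the two aromatic substituents in the set, bromo in compound 1 and isopropyl in compound 3, give numbers within the scatter of each other.

The step from compound 1 to compound 4, a 1.2-fold higher number from compound 1 to compound 4 (0.07 log units; within the scatter), is expected to stay within the scatter, with no direction claimed. Compound 4 is therefore estimated at 18000 nM, in the range 8000 nM to 40000 nM.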

Compound 4, half-maximal inhibitory concentration: 5590 nM
Compound 4: middle estimate off by 3.2-fold (0.51 log units), on the high side, and the stated range ends above it.
By their numbers in this assay, from the lowest: compound 4; then compounds 3 and 1 (each within the scatter of the next); then compound 2.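

In this assay, replacing bromo with methoxy on this aromatic carbon gives a 2.7-fold lower number from compound 1 to compound 4 (0.43 log units; beyond the scatter). Going by these compounds alone, this is the first step read from a matched pair, and it shows that the number responds to what sits at this position, which compounds 1 to 3 alone could not show. No measurement on hand accounts for the step.

From the compounds shown here alone, the reading rests on a single pair, so it is unknown whether the same change would give a similar step on the core of compound 3 or at another place on the ring. Going by these compounds, it also remains open whether the lower number belongs to methoxy specifically or would extend to other groups on the same carbon, such as hydroxy, ethoxy or an amine.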